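The compounds below may be only part of what the source reports. "The series", "measured", "known", "first", "only" and "open" are said of these compounds alone.

Values measured in a functional assay on MDA-MB-231 cells (Homo sapiens) for cytotoxicity, read by MTT assay, with a stated time of 72 h (on this read-out higher numbers stand for weaker inhibition and lower numbers for stronger inhibition), are these:
- compound 1 `O=C(CN1CCN(c2nnc(Cc3ccncc3)c3ccccc23)CC1)Nc1ccc(Br)cc1` gives 19 nM as its value
- compound 2 `O=C(CN1CCN(c2nnc(Cc3ccncc3)c3ccccc23)CC1)Nc1ccc(F)c(C(F)(F)F)c1` gives 1.9 nM as its value

Compound 2 stands lowest of the two at 1.9 nM on this read-out. Compound 3 `Cc1ccc(F)cc1NC(=O)CN1CCN(c2nnc(Cc3ccncc3)c3ccccc23)CC1` has 5-fluoro-2-methylphenyl in place of 4-fluoro-3-(trifluoromethyl)phenyl on an amide-type nitrogen and is otherwise unchanged. For the measured compounds named here, the one measured step at this place is a 10-fold lower number from compound 1 to compound 2 (1.00 log units; beyond the scatter) and it lies beyond the scatter. Going by the values given here, no measured compound carries the entering group. Given a 10-fold lower number from compound 1 to compound 2 (1.00 log units; beyond the scatter) at this same place, a rise of similar or smaller size is expected in this assay for compound 3. The expected change is a 4.2-fold higher number from compound 2 to compound 3 (0.62 log units; beyond the scatter) on this estimate. Compound 3 is estimated at 8 nM with an expected range of 2 nM to 35 nM on this read-out.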

Compound 3, half-maximal inhibitory concentration: 6.4 nM
Compound 3: the middle estimate sits 1.3-fold (0.10 log units) above what was measured; the measured number falls inside the stated range.
By their numbers in this assay, from the lowest: compound 2; then compound 3; then compound 1.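

With 5-fluoro-2-methylphenyl on the amide-type nitrogen, this assay shows a 3.4-fold higher number from compound 2 to compound 3 (0.53 log units; beyond the scatter) but also a 3.0-fold lower number from compound 1 to compound 3 (0.47 log units; beyond the scatter) on the same read-out. A methyl-bearing group with fewer heavy atoms therefore ranks between the two earlier aryl groups, so trifluoromethyl is not required to outdo 4-bromophenyl among these three compounds. Nothing available explains this order. The compounds shown leave open how a pyridine ring or a cyclohexyl group would read on this nitrogen, and whether a methoxy group, an amine or a carboxylic acid on the phenyl ring would be accepted.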